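From Carbamoyl Back to an Aryl Sulfonyl Group

A few compounds are considered here, and "the series" means these few. Any claim that something is new, unique, unknown or untested is made for them only; others in the source may bear on it.

In a functional assay on K562 cells (Homo sapiens) for inhibition, read by trypan blue exclusion, with a stated time of 72 h (a higher number here means a weaker inhibitor, a lower number a stronger inhibitor), three compounds sharing one core have been measured. Compound 1 `Cn1c(=O)c(S(=O)(=O)Cc2ccc(F)cc2)cc2cnc(Nc3ccc4[nH]ccc4c3)nc21` gives 30000 nM with a (4-fluorobenzyl)sulfonyl group, compound 2 `COc1ccc(S(=O)(=O)c2cc3cnc(Nc4ccc5[nH]ccc5c4)nc3n(C)c2=O)cc1` gives 300 nM with a (4-methoxyphenyl)sulfonyl group, and compound 3 `Cn1c(=O)c(C(=O)Nc2ccc(F)cc2)cc2cnc(Nc3ccc4[nH]ccc4c3)nc21` gives 5000 nM with a (4-fluorophenyl)carbamoyl group, the second highest of the three numbers. Compound 4 `Cn1c(=O)c(S(=O)(=O)c2ccc(O)cc2)cc2cnc(Nc3ccc4[nH]ccc4c3)nc21` is still unmeasured. It differs from compound 3 by (4-hydroxyphenyl)sulfonyl in place of (4-fluorophenyl)carbamoyl on an aromatic carbon.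

The closest evidence is the large step of a 17-fold higher number from compound 2 to compound 3 (1.22 log units; beyond the scatter) with (4-fluorophenyl)carbamoyl in place of (4-methoxyphenyl)sulfonyl. Compound 4 resembles compound 2, with 4-hydroxyphenyl in place of 4-methoxyphenyl on the sulfonyl sulfur, so that step should largely reverse. The (4-fluorobenzyl)sulfonyl group goes against any general sulfonyl advantage, as seen in a 6.0-fold lower number from compound 1 to compound 3 (0.78 log units; beyond the scatter) and in a 100-fold lower number from compound 1 to compound 2 (2.00 log units; beyond the scatter) with 4-methoxyphenyl on the sulfur. A large move to a lower number is therefore expected in this assay for this change, an estimated 13-fold lower number from compound 3 to compound 4 (1.10 log units; beyond the scatter) in all. For compound 4 the expected value is 400 nM (estimated range 100 nM to 1600 nM).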

Compound 4, half-maximal inhibitory concentration: 100 nM
Compound 4: middle estimate off by 4.0-fold (0.60 log units), on the high side, and the stated range covers the measured number.
By their numbers in this assay, from the lowest: compound 4; then compound 2; then compound 3; then compound 1.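

In this assay the step of a 50-fold lower number from compound 3 to compound 4 (1.70 log units; beyond the scatter) shows that the gain from an aryl sulfonyl group over the (4-fluorophenyl)carbamoyl group at this aromatic carbon is not confined to the 4-methoxyphenyl case, and compound 4 now has the lowest number of the four compounds. Going by these compounds alone, the ring on the sulfur also proves sensitive to a small edit: the step of a 3.0-fold lower number from compound 2 to compound 4 (0.48 log units; beyond the scatter) comes from hydrogen in place of methyl on the oxygen alone, a change beyond the scatter, whereas the earlier compounds offered no comparison between two aryl sulfonyl groups. The step of a 300-fold lower number from compound 1 to compound 4 (2.48 log units; beyond the scatter) widens the gap between these aryl sulfonyl compounds and the (4-fluorobenzyl)sulfonyl group of compound 1, which still stands against any general sulfonyl advantage.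

Nothing measured here bears on why the hydroxy compound differs from the methoxy compound.

The compounds shown leave open whether an amine or a carboxylic acid in place of the hydroxy group would hold the low number, and whether a (4-fluorophenyl)sulfonyl group or a (4-hydroxyphenyl)carbamoyl group would separate the contribution of the sulfonyl link from that of the ring substituent.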